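The source may report more compounds than this note shows. Statements on the series, on what has been measured and on what is new or still open speak of the compounds shown alone.

Measured so far in a functional assay for inhibition, with Homo sapiens as the target; on this read-out higher numbers stand for weaker binding and lower numbers for tighter binding:
- compound 1, `N#Cc1ccc(C2OCC(C/C=C\CCC(=O)O)C(c3cccnc3)O2)cc1`, gives 1290 nM
- compound 2, `O=C(O)CC/C=C\CC1COC(c2ccc(Cl)cc2Cl)OC1c1cccnc1`, gives 891 nM

Compound 1 has the highest of the two numbers; its nearest neighbour is compound 2, with a 1.4-fold lower number from compound 1 to compound 2 (0.16 log units; within the scatter), a gap that stays within the usual scatter. The unmeasured compound 3, `O=C(O)CC/C=C\CC1COC(c2cccnc2)OC1c1cccnc1`, departs from compound 1 by pyridin-3-yl in place of 4-cyanophenyl on a saturated ring carbon. For the measured compounds named here, the only measured step that bears on this position is the one from compound 1 to compound 2, where the 4-cyanophenyl group was likewise exchanged for another aromatic group and the read-out hardly moved. On that basis compound 3 is expected to sit close to compound 1, with no step beyond the scatter in either direction in this assay, so the expected step is a 1.0-fold higher number from compound 1 to compound 3 (0.00 log units; within the scatter). The estimate for compound 3 is 1300 nM, within a range from 450 nM to 3800 nM.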

Compound 3, dissociation constant: 759 nM
For compound 3 the middle estimate is 1.7-fold (0.23 log units) above the measured one, and the stated range covers the measured number.
By their numbers in this assay, from the lowest: compounds 3, 2 and 1 (each within the scatter of the next).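

In this assay pyridin-3-yl on the saturated ring carbon between two ring oxygen atoms gives a 1.7-fold lower number from compound 1 to compound 3 (0.23 log units; within the scatter) against 4-cyanophenyl and a 1.2-fold lower number from compound 2 to compound 3 (0.07 log units; within the scatter) against 2,4-dichlorophenyl. Until now only aromatic rings of carbon alone had been compared at this position; a ring with a hetero atom, with 6 heavy atoms where 4-cyanophenyl has 8, also stays within the scatter of both other compounds. Nothing available here explains why these three groups give numbers so alike.

The compounds shown all carry a six-membered aromatic ring at this position, so it remains open whether a cyclohexyl ring or a plain methyl group would give a similar number. From the compounds shown here alone, whether an amine on the aromatic ring would shift the number beyond the scatter also remains open.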